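Removing a methyl from the methoxy: what happens to cell potency

The source may report more compounds than this note shows. Statements on the series, on what has been measured and on what is new or still open speak of the compounds shown alone.

Measured compounds:
- compound 1, `O=C(Nc1cccc(-n2cc(-c3ccncc3)c(-c3ccc(Cl)c(O)c3)n2)c1)Nc1cccc(C(F)(F)F)c1`: > 32500 nM
- compound 2, `COc1cc(-c2nn(-c3cccc(NC(=O)Nc4cc(C(F)(F)F)cc(C(F)(F)F)c4)c3)cc2-c2ccncc2)ccc1Cl`: 4830 nM

Compound 1 reaches only the limit of a functional assay on HCT-116 cells (Homo sapiens) for inhibition, read by sulforhodamine B assay, with a stated time of 48 h (a lower number here means that less compound is tolerated, a higher number that more compound is tolerated), and gives no number, at > 32500 nM. Going by the values given here, compound 2 is the only compound with a numerical value in this assay, 4830 nM. Among the compounds with values here, no two measured compounds differ in a single place, so no measured step is available.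

Compound 3, `O=C(Nc1cccc(-n2cc(-c3ccncc3)c(-c3ccc(Cl)c(O)c3)n2)c1)Nc1cc(C(F)(F)F)cc(C(F)(F)F)c1`, has not yet been tested in this assay. Compound 3 differs from compound 2 by hydrogen in place of methyl on an oxygen on an aromatic ring. Compound 1 also carries the hydroxy group and sits at the limit, while compound 2 with the methoxy group gives a number, but these two compounds differ in more than one place, so this comparison is only suggestive. Compound 3 is expected to be less potent than compound 2, with a step of a 2.7-fold higher number from compound 2 to compound 3 (0.43 log units; beyond the scatter), the expected value for compound 3 being 13000 nM within a range from 3500 nM to 40000 nM.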

Compound 3, concentration lethal to 50% of the cells: 2650 nM
Compound 3: middle estimate off by 4.9-fold (0.69 log units), on the high side; measured number below the stated range.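

In this assay the change from methoxy to hydroxy gives a 1.8-fold lower number from compound 2 to compound 3 (0.26 log units; within the scatter), so at this position the two groups cannot be told apart when the molecule carries two trifluoromethyl groups. The hydroxy group alone therefore does not put a compound at the limit, since trifluoromethyl in place of hydrogen on an aromatic carbon gives an at least 12-fold lower number from compound 1 to compound 3 (1.08 log units; beyond the scatter), a large step between two hydroxy compounds. The size of that step is only a minimum, as the value for compound 1 is a limit and not a number: the limit of > 32500 nM in this assay, at which 1 of the 3 values shown sits.

On these data alone, it remains open whether methoxy and hydroxy would also match in a compound with a single trifluoromethyl group. As far as these compounds go, how an amine or a longer chain such as ethoxy would read at this position is also open.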